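The source may hold more compounds than are shown below. What is called first, only, known or untested is meant among the compounds shown, and "the series" means these compounds.

Compound 1 `COc1cccc(N2CCN(CCCCN3C(=O)SC4(CCCC4)C3=O)CC2)n1` sits at the edge of what a functional assay on the whole organism for inhibition, with Rattus norvegicus as the target (a higher number here means that more compound is needed for the effect, a lower number that less compound is needed), can report. Compound 1 gives > 100 mg/kg, which is a limit and not a number. Compound 3 `O=C1SC2(CCCC2)C(=O)N1CCCCN1CCN(c2ncccc2-c2ccccc2)CC1` also gives only a limit, > 100 mg/kg. Within the data shown here, of the compounds measured so far, only compound 2 `O=C1SC2(CCCC2)C(=O)N1CCCCN1CCN(c2ncccc2[N+](=O)[O-])CC1` gives a number, 43.6 mg/kg.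

Compound 4 `O=C1SC2(CCCC2)C(=O)N1CCCCN1CCN(c2ncccc2Cl)CC1` is still unmeasured. It departs from compound 1 as follows: 3-chloropyridin-2-yl in place of 6-methoxypyridin-2-yl on an amine nitrogen in a ring. Thus 3-chloropyridin-2-yl stands in place of 6-methoxypyridin-2-yl on an amine nitrogen in a ring.

Among the measured compounds shown here, two measured steps bear on this change. The closer one is an at least 2.2-fold lower number from compound 1 to compound 2 (0.36 log units; beyond the scatter), where 3-nitropyridin-2-yl replaces the same 6-methoxypyridin-2-yl. The other is an at least 2.2-fold higher number from compound 2 to compound 3 (0.36 log units; beyond the scatter), with phenyl in place of nitro on an aromatic carbon, and it shows that the gain can be lost again. Compound 4 also carries a 3-substituted pyridin-2-yl group, so a modest move towards a lower number is expected, though it may fall short of the limit only narrowly or not at all. The expected step is an at least 1.6-fold lower number from compound 1 to compound 4 (0.22 log units; that floor lies within the scatter). For compound 4 the estimated value is 60 mg/kg, with an expected range from 25 mg/kg to 140 mg/kg.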

Compound 4, dose for half-maximal effect: 50 mg/kg
For compound 4 the middle estimate is 1.2-fold (0.08 log units) above the measured one; the range from low to high includes it.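

In this assay, chloro and nitro on this aromatic carbon cannot be told apart: a 1.1-fold higher number from compound 2 to compound 4 (0.06 log units; within the scatter). The measurable response of compound 2 is therefore not tied to the nitro group alone, although compound 3 shows that not every group on this carbon gives a number. Against the 6-methoxypyridin-2-yl group, the 3-chloropyridin-2-yl group gives an at least 2.0-fold lower number from compound 1 to compound 4 (0.30 log units; that floor lies within the scatter), and chloro in place of phenyl gives an at least 2.0-fold lower number from compound 3 to compound 4 (0.30 log units; that floor lies within the scatter); both floors lie within the scatter, and neither step has a known full size because one end of each is a limit and not a number: the limit of > 100 mg/kg in this assay, at which 2 of the 4 values shown sit.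

The compounds shown leave open whether fluoro, methyl or an amine on this aromatic carbon would also give a number in this assay, and whether a plain hydrogen there would return the response to the limit. They also leave open whether methoxy on this same carbon would match chloro and nitro, which would separate the identity of the group from its place on the pyridine.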